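From 3,4-dimethylphenyl to phenyl on the sulfonamide nitrogen

The source may hold more compounds than are shown below. What is called first, only, known or untested is meant among the compounds shown, and "the series" means these compounds.

In a functional assay on M21 cells (Homo sapiens) for antiproliferative activity, read by sulforhodamine B assay, with a stated time of 48 h (a higher number here means a weaker inhibitor, a lower number a stronger inhibitor), compound 1 (`O=C1NCCN1c1ccc(S(=O)(=O)Nc2ccc(C3CCCCC3)cc2)cc1`) reads > 1000 nM as its result, which is a limit and not a number. Compound 2 (`CCCCc1ccc(NS(=O)(=O)c2ccc(N3CCNC3=O)cc2)cc1`) gives 450 nM in the same read-out. Within the data shown here, compound 3 (`Cc1ccc(NS(=O)(=O)c2ccc(N3CCNC3=O)cc2)cc1C`) gives 94 nM as the lowest number so far.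

Compound 4 (`O=C1NCCN1c1ccc(S(=O)(=O)Nc2ccccc2)cc1`) has phenyl in place of 3,4-dimethylphenyl on a sulfonamide nitrogen, and phenyl in place of 3,4-dimethylphenyl on a sulfonamide nitrogen is the count of that change.

Among the measured compounds shown here, the one measured step, butyl in place of cyclohexyl on an aromatic carbon, shows an at least 2.2-fold lower number from compound 1 to compound 2 (0.34 log units; beyond the scatter) as its size, with one end resting on the limit of > 1000 nM in this assay, at which 1 of the 3 values shown sits, and so open-ended. It removes no methyl group and bears only indirectly, showing that the group on the sulfonamide nitrogen side can move the number beyond the scatter.

Since compound 3 sits lowest at 94 nM in this set, a move to a higher number is expected. The expected change is a 5.3-fold higher number from compound 3 to compound 4 (0.73 log units; beyond the scatter) in this assay as a weaker inhibitor. For compound 4 the estimate is 500 nM as a central value, with an expected range of 130 nM to 2000 nM around it.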

Compound 4, half-maximal inhibitory concentration: 200 nM
Compound 4: the middle estimate sits 2.5-fold (0.40 log units) above what was measured, within the range that was stated.
By their numbers in this assay, from the lowest: compound 3; then compound 4; then compound 2. At a limit, above all of these: compound 1.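

In this assay, the 3,4-dimethylphenyl on the sulfonamide nitrogen holds only a modest edge over plain phenyl, with a 2.1-fold higher number from compound 3 to compound 4 (0.33 log units; beyond the scatter). Substitution on this phenyl does not act in one direction, since the two methyl groups of compound 3 give a lower number than phenyl, while the butyl group of compound 2 goes against that, with a 2.3-fold lower number from compound 2 to compound 4 (0.35 log units; beyond the scatter). Cyclohexyl fares worse still, with an at least 5.0-fold lower number from compound 1 to compound 4 (0.69 log units; beyond the scatter), and that step stays open-ended, as the result for compound 1 is a limit and not a number: the limit of > 1000 nM in this assay, at which 1 of the 4 values shown sits.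

The compounds shown leave open whether a single methyl group would carry the effect of the 3,4-dimethylphenyl. They also leave open how a chlorine, a methoxy group or an amine on the phenyl would read.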